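This account rests on a few compounds, and the source may have more. Where it says the series, first, only, none or still open, it means among the compounds named here.

Measured compounds, with their numbers in a functional assay on A549 cells (Homo sapiens) for cytotoxicity, read by MTT assay; on this read-out lower numbers stand for stronger inhibition and higher numbers for weaker inhibition:

compound 1 `C=C1C(=O)[C@]23C[C@@]1(Cl)CC[C@H]2[C@@]12C=CC(=O)[C@](C)(C(=O)O1)[C@H]2[C@@H]3C(=O)OC` gives 60300 nM
compound 2 `C=C1C(=O)[C@]23C[C@@]1(Cl)CC[C@H]2[C@@]12C=CC(=O)[C@](C)(C(=O)O1)[C@H]2[C@@H]3C(=O)OCc1ccccc1` gives 28800 nM
compound 3 `C=C1C(=O)[C@]23C[C@@]1(OCC)CC[C@H]2[C@@]12C=CC(=O)[C@](C)(C(=O)O1)[C@H]2[C@@H]3C(=O)OC` gives 18200 nM

Compound 2 stands second highest of the three numbers. Its nearest neighbour is compound 3, whose number lies within the scatter of that of compound 2, so no order between the two can be read. Compound 1 gives the highest number; the step of a 2.1-fold lower number from compound 1 to compound 2 (0.32 log units; beyond the scatter) lies beyond the scatter and is modest in size.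

Compound 4 `C=C1C(=O)[C@]23C[C@@]1(OCC)CC[C@H]2[C@@]12C=CC(=O)[C@](C)(C(=O)O1)[C@H]2[C@@H]3C(=O)OCc1ccccc1` has not been measured. Relative to compound 2 the change is ethoxy in place of chloro on a saturated ring carbon.

The same exchange has been observed once in the series, on the methyl ester rather than the benzyl ester: a 3.3-fold lower number from compound 1 to compound 3 (0.52 log units; beyond the scatter). That step was modest but beyond the scatter. Among the measured compounds shown here, it is the only step that bears on the present one; whether the lowering recurs on the benzyl ester of compound 2 cannot be checked against a second example, and the two measured steps together do not establish any additivity.

On this single precedent a lowering of roughly the same size is expected for compound 4, that is a 3.2-fold lower number from compound 2 to compound 4 (0.51 log units; beyond the scatter) is the expected step. For the measured compounds named here, compound 4 is accordingly estimated at 9000 nM, with a range from 4000 nM to 20000 nM allowing for the scatter and for the single supporting step.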

Compound 4, half-maximal inhibitory concentration: 24200 nM
Compound 4: the middle estimate sits 2.7-fold (0.43 log units) below what was measured; measured number outside the range, above it.
By their numbers in this assay, from the lowest: compounds 3, 4 and 2 (each within the scatter of the next); then compound 1.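

In this assay the exchange of chloro for ethoxy on a saturated ring carbon, made on the benzyl ester, gives a 1.2-fold lower number from compound 2 to compound 4 (0.08 log units; within the scatter) and so does not repeat the lowering seen on the methyl ester: the same change on two cores in this assay, a 3.3-fold lower number (0.52 log units; beyond the scatter) from compound 1 to compound 3 and a 1.2-fold lower number (0.08 log units; within the scatter) from compound 2 to compound 4, 2.8-fold (0.44 log units) apart, beyond the scatter of two such steps

The phenyl change on the ester side depends in the same way on the group at this ring position, since with ethoxy in place it gives a 1.3-fold higher number from compound 3 to compound 4 (0.12 log units; within the scatter) and no longer the lowering seen with chloro: the same change on two cores in this assay, a 2.1-fold lower number (0.32 log units; beyond the scatter) from compound 1 to compound 2 and a 1.3-fold higher number (0.12 log units; within the scatter) from compound 3 to compound 4, 2.8-fold (0.44 log units) apart, beyond the scatter of two such steps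

Each change alone lowers the number from compound 1, but on these four compounds the second change adds nothing that can be read on top of the first, so the two steps do not add.

On these data alone, whether this holds for other groups on the same ring carbon remains open, for instance an amine or a longer chain such as butoxy. As far as these compounds go, it is also open whether a free carboxylic acid in place of the ester would leave the number unchanged with either chloro or ethoxy on that carbon.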